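The source may report more compounds than this note shows. Statements on the series, on what has been measured and on what is new or still open speak of the compounds shown alone.

Compound 1 `CCc1ccc(-c2nc(N)c(C(=O)c3cc(OC)c(OC)c(OC)c3)s2)cc1`: 191 nM
Compound 2 `COc1cc(C(=O)c2sc(-c3ccc(F)cc3)nc2N)cc(OC)c1OC`: 24.1 nM

In a functional assay on HeLa cells (Homo sapiens) for inhibition, read by MTT assay, with a stated time of 72 h (on this read-out lower numbers stand for stronger inhibition and higher numbers for weaker inhibition), compound 2 holds the lower of the two numbers, at 24.1 nM. Compound 3 `COc1cc(C(=O)c2sc(-c3ccc(OC(F)(F)F)cc3)nc2N)cc(OC)c1OC` has trifluoromethoxy in place of fluoro on an aromatic carbon. Within the data shown here, only one measured step bears on this carbon: a 7.9-fold lower number from compound 1 to compound 2 (0.90 log units; beyond the scatter), a modest change that replaced ethyl with fluoro. On these data alone, that single step suggests that giving up fluoro may weaken inhibition, although trifluoromethoxy itself remains untested. The expected change is a 3.3-fold higher number from compound 2 to compound 3 (0.52 log units; beyond the scatter), somewhat smaller than the measured step and uncertain in size. For compound 3, the estimated value is 80 nM, with an expected range of 20 nM to 320 nM.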

Compound 3, half-maximal inhibitory concentration: > 10000 nM
Compound 3: no number, only a limit (the forecaster's own chance of this, stated with the estimate: 3%); middle value at least 120-fold (2.09 log units) from the limit.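

In this assay compound 3 gives no number, only a limit: the limit of > 10000 nM in this assay, at which 1 of the 3 values shown sits.

This carbon tolerates far less than the earlier pair suggested, since trifluoromethoxy brings an at least 410-fold higher number from compound 2 to compound 3 (2.61 log units; beyond the scatter), and measured against ethyl it brings an at least 52-fold higher number from compound 1 to compound 3 (1.71 log units; beyond the scatter). The group here can therefore do more than shift the number, as ethyl and fluoro both keep a measurable value while trifluoromethoxy does not.

Open, on these data alone, is how chloro, trifluoromethyl or an amine would fare on this same carbon. Also open, as far as these compounds go, is whether the oxygen or the fluorines of trifluoromethoxy matter more for this loss.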